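The source may report more compounds than this note shows. Statements on the series, on what has been measured and on what is new or still open speak of the compounds shown alone.

Three compounds have been measured in a functional assay on Raji cells (Homo sapiens) for antiproliferative activity, read by CCK-8 assay, with a stated time of 72 h, tested at 40 uM; on this read-out higher numbers stand for more inhibition at the one concentration tested (going by the name of the read-out) and lower numbers for less inhibition:

compound 1, `CCOC(=O)c1sc(-c2cccc(NC(=O)c3ccc(Cl)cc3)c2)nc1Nc1ccc(N2CCN(C)CC2)cc1`, gives 24.3%
compound 2, `CCOC(=O)c1sc(-c2cccc(NC(=O)c3ccc(F)c(Cl)c3)c2)nc1Nc1ccc(N2CCN(C)CC2)cc1`, gives 20.7%
compound 3, `CN1CCN(c2ccc(Nc3nc(-c4cccc(NC(=O)c5ccc(Cl)cc5)c4)sc3C(N)=O)cc2)CC1`, gives 92.6%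

Compound 1 and compound 2 share one core and differ only in the acyl group on the amide: 3-chloro-4-fluorophenyl in place of 4-chlorophenyl on a carbonyl carbon. This change gave a number 3.6 percentage points lower from compound 1 to compound 2 (within the scatter), so the two values show no real difference. Compound 3 carries a different core than compound 1, and that difference is amino in place of ethoxy on a carbonyl carbon; it gave a number 68.3 percentage points higher from compound 1 to compound 3 (beyond the scatter), the highest value of the three, beyond the scatter from both others.

Compound 4, `CN1CCN(c2ccc(Nc3nc(-c4cccc(NC(=O)c5ccc(F)c(Cl)c5)c4)sc3C(N)=O)cc2)CC1`, is not yet measured. It stands to compound 3 as compound 2 stands to compound 1: 3-chloro-4-fluorophenyl in place of 4-chlorophenyl on a carbonyl carbon, at a place described in the same words as before, so it is the same change made on the core of compound 3. Since the earlier step was a number 3.6 percentage points lower from compound 1 to compound 2 (within the scatter), the step from compound 3 to compound 4 is expected to be about a number 4.6 percentage points lower from compound 3 to compound 4 (within the scatter), again within the scatter. Compound 4 is therefore estimated to give 88% in this assay, with a likely range from 70% to 98%.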

Compound 4, a percentage reported as inhibition, at one concentration (the size of the read-out at that concentration, not a potency): 94.4%
Estimate against measurement, compound 4: 6.4 percentage points below, and the stated range covers the measured number.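

In this assay, putting 3-chloro-4-fluorophenyl in place of 4-chlorophenyl on a carbonyl carbon gave a number 1.8 percentage points higher from compound 3 to compound 4 (within the scatter), and this step matches the one seen on the core of compound 1: the same change on two cores in this assay, a number 3.6 percentage points lower (within the scatter) from compound 1 to compound 2 and a number 1.8 percentage points higher (within the scatter) from compound 3 to compound 4, 5.4 percentage points apart, within the scatter of two such steps

Amino in place of ethoxy on a carbonyl carbon also carried over, giving a number 73.7 percentage points higher from compound 2 to compound 4 (beyond the scatter), and its size held whichever aromatic group was present: the same change on two cores in this assay, a number 68.3 percentage points higher (beyond the scatter) from compound 1 to compound 3 and a number 73.7 percentage points higher (beyond the scatter) from compound 2 to compound 4, 5.4 percentage points apart, within the scatter of two such steps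

So in these four compounds the two changes acted independently, but each comparison rests on a single pair of steps at one concentration, which shows neither how potency changes nor whether other groups would behave the same way.

The compounds shown leave open whether the large gain requires the plain amino group, or whether methylamino, dimethylamino or a carboxylic acid on that carbonyl carbon would give a similar number. They also leave open whether an acyl group carrying a pyridine ring instead of a halogenated phenyl ring would keep the high inhibition.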